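The compounds below may be only part of what the source reports. "The series", "measured", "known", "first", "only" and "open" are said of these compounds alone.

In a toxicity assay on KB cells (Homo sapiens) for cytotoxicity, read by fluorescence, with a stated time of 3 days (on this read-out higher numbers stand for an effect only at larger amounts of compound and lower numbers for an effect already at smaller amounts), compound 1 `CCCCOC(=O)CNC(=O)[C@H](CSc1ccc([N+](=O)[O-])cc1[N+](=O)[O-])NC(=O)CC[C@H](NC(=O)CC(C)C)C(=O)OCCCC` gives 59.6 uM, and compound 2 `CCCCOC(=O)CNC(=O)[C@H](CSc1ccc([N+](=O)[O-])cc1[N+](=O)[O-])NC(=O)CC[C@H](NC(=O)CC(C)(C)C)C(=O)OCCCC` gives 250 uM. Among the compounds with values here, compound 2 thus stands at the highest of the two numbers measured so far, with compound 1 as its only neighbour. Within the data shown here, the single step between them, methyl in place of hydrogen on a saturated chain carbon bound to three saturated chain carbons, brought a 4.2-fold higher number from compound 1 to compound 2 (0.62 log units; beyond the scatter). Compound 3 `CCCCCCCCCCCCCC(=O)N[C@@H](CCC(=O)N[C@@H](CSc1ccc([N+](=O)[O-])cc1[N+](=O)[O-])C(=O)NCC(=O)OCCCC)C(=O)OCCCC` has not yet been measured in this assay. It differs from compound 2 by dodecyl in place of tert-butyl on a saturated chain carbon bound to a carbonyl carbon. Among the measured compounds shown here, the one measured step bears on this change only loosely: it altered the same small group that is now replaced outright, but it added a single methyl, whereas here a far longer chain enters. For the measured compounds named here, that step was modest and pointed toward a higher number; a chain of this length is a change of another kind, and nothing among the measured compounds shows its consequence. For compound 3 a step of a 2.5-fold lower number from compound 2 to compound 3 (0.40 log units; beyond the scatter) in this assay is therefore expected, with little confidence in its direction. The estimate for compound 3 is 100 uM, within a range from 25 uM to 400 uM.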

Compound 3, concentration for half-maximal effect: > 300 uM
Compound 3 ended at the assay's limit; the forecaster's own chance of this, stated with the estimate: 10%; middle value at least 3.0-fold (0.47 log units) away from the limit.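

In this assay compound 3 gives > 300 uM, which is a limit of the assay and not a number: the limit of > 300 uM in this assay, at which 1 of the 3 values shown sits. Measured against the isopropyl group on a saturated chain carbon bound to a carbonyl carbon, dodecyl brings an at least 5.0-fold higher number from compound 1 to compound 3 (0.70 log units; beyond the scatter), so a long chain at this place moves the read-out in the same direction as the single added methyl did, a 4.2-fold higher number from compound 1 to compound 2 (0.62 log units; beyond the scatter), and compound 1 keeps the lowest number of the three. Against tert-butyl, the change gives an at least 1.2-fold higher number from compound 2 to compound 3 (0.07 log units; that floor lies within the scatter), and since that floor lies within the scatter, the data show no separation of dodecyl from tert-butyl, although the true gap could be larger.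

Going by these compounds, how far compound 3 really lies past its limit stays open, and with it whether the number keeps rising with chain length or levels off once the group at this place is larger than isopropyl. Also open, on these data alone, is what a chain of middling length, such as hexyl, or a chain ending in an amine or a carboxylic acid would give at this place.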